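This account rests on a few compounds, and the source may have more. Where it says the series, first, only, none or still open, it means among the compounds named here.

Compound 1, `Nc1nc(N2CCCC2)c2ncn(/C=C3/CC3(CO)CO)c2n1`: > 20000 nM in an ADME assay on CCRF-HSB-2 cells (Homo sapiens) for cytotoxicity, with a stated time of 7 days (on this read-out higher numbers stand for lower toxicity in this test and lower numbers for higher toxicity in this test), a limit of the assay rather than a number.
Compound 2, `CSc1nc(N)nc2c1ncn2/C=C1/CC1(CO)CO`: > 100000 nM, again a limit.
Compound 3, `Nc1nc(SC2CCCC2)c2ncn(/C=C3/CC3(CO)CO)c2n1`: 91000 nM.

Compound 3 is the only one of the three whose value is a number. The value of compound 1 is a limit. The value of compound 2 is likewise a limit. Among the compounds with values here, the only step that can be read, an at least 1.0-fold lower number from compound 2 to compound 3 (0.04 log units; that floor lies within the scatter), lies within the scatter; the steps starting from compound 1 cannot be read because of the limit of > 20000 nM in this assay, at which 1 of the 3 values shown sits.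

Compound 4, `CCCCOc1nc(N)nc2c1ncn2/C=C1/CC1(CO)CO`, differs from compound 3 by butoxy in place of cyclopentylsulfanyl on an aromatic carbon. Within the data shown here, no measured step matches this change, and the one readable step showed no movement beyond the scatter, so no step beyond the scatter is expected in this assay. Compound 4 is estimated at 90000 nM, between 30000 nM and 300000 nM, an expected step of a 1.0-fold lower number from compound 3 to compound 4 (0.00 log units; within the scatter).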

Compound 4, half-maximal cytotoxic concentration: > 20000 nM
Compound 4 ended at the assay's limit; the forecaster's own chance of this, stated with the estimate: 50%; the middle value does not contradict the limit.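

Within the data shown here, compound 4 gave only a limit, so no step linking it to compound 1, compound 2 or compound 3 can be read in this assay. On these data alone, how far butoxy differs from the other three groups remains open.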